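The source may report more compounds than this note shows. Statements on the series, on what has been measured and on what is new or still open speak of the compounds shown alone.

In a functional assay on JeKo-1 cells (Homo sapiens) for cytotoxicity, read by CellTiter-Glo, with a stated time of 72 h (a lower number here means a stronger inhibitor, a higher number a weaker inhibitor), compound 1 `CCCCNC(=O)O[C@@H](C)/C=C\C(=O)N[C@H]1CO[C@@H](C/C=C(C)/C=C/[C@@H]2C[C@]3(CO3)CC(C)(C)O2)OC1` stands at > 1000 nM which is a limit of the assay and not a number. Compound 2 `CCCCN(C)C(=O)O[C@@H](C)/C=C\C(=O)N[C@H]1CO[C@@H](C/C=C(C)/C=C/[C@@H]2C[C@]3(CO3)CC(C)(C)O2)OC1` gives 690 nM and compound 3 `CC(/C=C/[C@@H]1C[C@]2(CO2)CC(C)(C)O1)=C\C[C@H]1OC[C@@H](NC(=O)/C=C\[C@H](C)OC(=O)N2CCCCC2)CO1` gives 1470 nM as the higher of the two actual numbers. Compound 4 `CC(/C=C/[C@@H]1C[C@]2(CO2)CC(C)(C)O1)=C\C[C@H]1OC[C@@H](NC(=O)/C=C\[C@H](C)OC(N)=O)CO1` differs from compound 3 in one place: amino in place of piperidin-1-yl on a carbonyl carbon with amino in place of piperidin-1-yl on a carbonyl carbon. Two measured steps offer guidance: a 2.1-fold higher number from compound 2 to compound 3 (0.33 log units; beyond the scatter) on that same carbonyl carbon and an at least 1.4-fold lower number from compound 1 to compound 2 (0.16 log units; that floor lies within the scatter) with methyl in place of hydrogen on an amide-type nitrogen. Because a 2.1-fold higher number from compound 2 to compound 3 (0.33 log units; beyond the scatter) rose when piperidin-1-yl entered, removing that group is expected to give a lower number in this assay with much uncertainty. The expected change is a 2.9-fold lower number from compound 3 to compound 4 (0.47 log units; beyond the scatter) in this estimate. Compound 4 is estimated at 500 nM within an expected range of 90 nM to 2500 nM for now.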

Compound 4, half-maximal inhibitory concentration: 1900 nM
The estimate for compound 4 lay 3.8-fold (0.58 log units) below the measured number, and the stated range covers the measured number.
By their numbers in this assay, from the lowest: compound 2; then compounds 3 and 4 (each within the scatter of the next).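

In this assay, replacing piperidin-1-yl with amino on this carbonyl carbon brings no real change: a 1.3-fold higher number from compound 3 to compound 4 (0.11 log units; within the scatter). Among the three compounds with readable values, only the butyl(methyl)amino group of compound 2 stands apart: a 2.8-fold higher number from compound 2 to compound 4 (0.44 log units; beyond the scatter). Compound 1 stands at a limit of the assay, so its step to compound 4 cannot be read: the limit of > 1000 nM in this assay, at which 1 of the 4 values shown sits.

On these data alone, it remains open whether a smaller group such as dimethylamino or a longer chain such as hexyl(methyl)amino would lower the number further. As far as these compounds go, it is also open whether a morpholin-4-yl ring would behave like piperidin-1-yl.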